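Growing a Side Group While Cytotoxicity Stays Unreadable

The compounds below may be only part of what the source reports. "The series", "measured", "known", "first", "only" and "open" are said of these compounds alone.

Compound 1 `COc1ccc2c(c1)[C@@H](O)CN(C)C2` and compound 2 `CN1Cc2ccc(OCc3ccccc3)cc2[C@@H](O)C1` share one core and differ at a single spot. In an ADME assay on Vero cells (Chlorocebus sabaeus) for cytotoxicity, read by sulforhodamine B assay, with a stated time of 72 h (a lower number here means a stronger inhibitor, a higher number a weaker inhibitor), compound 1 gives > 100000 nM, which is a limit of the assay rather than a measured number. In this assay compound 2 gives > 100000 nM, again a limit and not a number. Among the measured compounds shown here, the one step between them, a step that the two limits leave unreadable from compound 1 to compound 2, is phenyl in place of hydrogen on a saturated chain carbon bound to an oxygen on an aromatic ring; because of the limit of > 100000 nM in this assay, at which 2 of the 2 values shown sit, its size cannot be read in either direction. Compound 3 `CN1Cc2ccc(OCc3ccc(-c4ccccc4)cc3)cc2[C@@H](O)C1` carries one further change relative to compound 2: phenyl in place of hydrogen on an aromatic carbon. For the measured compounds named here, the only step seen so far, from compound 1 to compound 2, bears on this change merely by showing that a comparable addition left both compounds at the limit, so no movement beyond the scatter is expected here. Compound 3 is therefore expected to sit near 100000 nM, within 30000 nM and 300000 nM, most probably reported once more as a limit. The expected step from compound 2 to compound 3 is a number no higher from compound 2 to compound 3 (the limit leaves the size open), essentially none.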

Compound 3, half-maximal inhibitory concentration: 23000 nM
The estimate for compound 3 lay 4.3-fold (0.64 log units) above the measured number; measured number outside the range, below it.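

Among the compounds shown here, the second phenyl, on an aromatic carbon para to a large group, is the first change in this short series to bring the read-out off the limit: in this assay it gives an at least 4.3-fold lower number from compound 2 to compound 3 (0.63 log units; beyond the scatter). Compound 2 gives > 100000 nM, which is a limit and not a number, so this step is known only as a minimum and the real drop may be larger. The earlier step, from compound 1 to compound 2, cannot be read, and it gave no sign of this effect on the cells because both of its compounds sit at the limit: the limit of > 100000 nM in this assay, at which 2 of the 3 values shown sit.

The compounds shown do not tell whether the drop belongs to the phenyl ring itself or would also follow from another group on that same aromatic carbon, such as a methoxy group, an amine or a carboxylic acid. For the compounds shown here, with compound 3 as the only readable value, they also give no trend, so how the number would move with a still larger group at this place remains unknown.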